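The compounds below may be only part of what the source reports. "The series", "measured", "known", "first", "only" and "open" are said of these compounds alone.

Compound 1 `CNC(=O)[C@@]12C[C@@H]1[C@@H](n1cnc3c(NC)nc(C#Cc4ccc(OC)cc4)nc31)[C@H](O)[C@@H]2O` and compound 2 `CNC(=O)[C@@]12C[C@@H]1[C@@H](n1cnc3c(NC)nc(C#Cc4cccc(C(F)(F)F)c4)nc31)[C@H](O)[C@@H]2O` share one core and differ only in the group carried on a triple-bonded carbon. In an assay on CHO cells for displacement of a labelled ligand from adenosine receptor A1 (Homo sapiens), read by scintillation counting, with a stated time of 60 min, tested at 10 uM (on this read-out higher numbers stand for more inhibition at the one concentration tested (going by the name of the read-out) and lower numbers for less inhibition), compound 1 gives 10%, and in this assay compound 2 gives 10%. The step of no change at the digits printed from compound 1 to compound 2 (within the scatter) left the read-out where it was, within the scatter, so compound 2 stands level with compound 1 at the digits shown, and both sit at a low level of inhibition.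

Compound 3 `CNC(=O)[C@@]12C[C@@H]1[C@@H](n1cnc3c(NC)nc(C#Cc4cccnn4)nc31)[C@H](O)[C@@H]2O` remains to be measured. Its change from compound 2 is pyridazin-3-yl in place of 3-(trifluoromethyl)phenyl on a triple-bonded carbon. Going by the values given here, the only measured step that bears on this place is the one from compound 1 to compound 2, which was flat, and it exchanged one aromatic carbon ring for another; no measured step covers a ring with hetero atoms at this position. On that basis a step of a number 2 percentage points higher from compound 2 to compound 3 (within the scatter) is expected for compound 3 in this assay, none beyond the scatter, with wide uncertainty. Compound 3 is therefore estimated at 12%, within a range from 0% to 35%.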

Compound 3, a percentage reported as inhibition, at one concentration (the size of the read-out at that concentration, not a potency): 11%
For compound 3 the middle estimate is 1 percentage points above the measured one; low and high end bracket the measured number.
By their numbers in this assay, from the lowest: compounds 1, 2 and 3 (each within the scatter of the next).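

In this assay, going by these compounds alone, the exchange of 3-(trifluoromethyl)phenyl for pyridazin-3-yl on a triple-bonded carbon gives a number 1 percentage points higher from compound 2 to compound 3 (within the scatter), and this is the first measured step at this position to bring in a ring with hetero atoms. The exchange of 4-methoxyphenyl for the same ring gives a number 1 percentage points higher from compound 1 to compound 3 (within the scatter), so the flat reading, which the earlier pair showed only for rings of carbon only, now also holds for a six-membered aromatic ring with 2 hetero atoms. No evidence at hand bears on the reason for this flat reading.

Going by these compounds, all three compounds carry a six-membered aromatic ring at this place, so it remains open whether an amine, a carboxylic acid or a longer alkyl chain on the triple-bonded carbon would move the reading in this assay beyond the scatter. Also open is whether a change elsewhere on the shared core, such as at the methylamide, would do so, since only this one position varies among the compounds shown.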